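This account rests on a few compounds, and the source may have more. Where it says the series, first, only, none or still open, it means among the compounds named here.

Compound 1 `CC/C(=C(/c1ccc(/C=C/C(=O)O)cc1)c1cc2ccccc2[nH]1)c1ccccc1Cl`: 42 nM
Compound 2 `CC/C(=C(/c1ccc(/C=C/C(=O)O)cc1)c1cc2ccccc2[nH]1)c1cccc(C)c1`: 140 nM
Compound 3 `CC/C(=C(/c1ccc(/C=C/C(=O)O)cc1)c1cc2ccccc2[nH]1)c1ccc(F)cc1Cl`: 39 nM

All three compounds share one core and differ only in the aromatic ring attached to it, and all were measured in a functional assay on MCF7 cells (Homo sapiens) for inhibition; on this read-out higher numbers stand for weaker inhibition and lower numbers for stronger inhibition. Compound 2 holds the highest number of the three. The step of a 3.3-fold higher number from compound 1 to compound 2 (0.52 log units; beyond the scatter) shows that exchanging the 2-chlorophenyl of compound 1 for the 3-methylphenyl of compound 2 weakens inhibition modestly, and the step of a 3.6-fold lower number from compound 2 to compound 3 (0.56 log units; beyond the scatter) shows the reverse kind of exchange strengthening it by a similar amount. Between compound 1 and compound 3 the step is a 1.1-fold lower number from compound 1 to compound 3 (0.03 log units; within the scatter), so the added fluorine made no difference that can be separated from the scatter.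

Compound 4 `CC/C(=C(/c1ccc(/C=C/C(=O)O)cc1)c1cc2ccccc2[nH]1)c1c(C)cccc1Cl` is not yet measured. It differs from compound 2 in one place: 2-chloro-6-methylphenyl in place of 3-methylphenyl on a double-bonded chain carbon bound to a double-bonded chain carbon and a saturated chain carbon. The ring that enters carries the same chlorine that sits in compound 1 and compound 3, together with an extra methyl, for which no comparison exists here. Both measured steps that replace the 3-methylphenyl with a chlorine-bearing ring point the same way, so a modest step to a lower number is expected, a 2.8-fold lower number from compound 2 to compound 4 (0.45 log units; beyond the scatter), with the added methyl leaving the size uncertain. For compound 4 the expected value in this assay is 50 nM, within a range from 20 nM to 130 nM.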

Compound 4, half-maximal inhibitory concentration: 30 nM
The estimate for compound 4 lay 1.7-fold (0.22 log units) above the measured number; low and high end bracket the measured number.
By their numbers in this assay, from the lowest: compounds 4, 3 and 1 (each within the scatter of the next); then compound 2.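

In this assay, placing 2-chloro-6-methylphenyl on the double-bonded chain carbon instead of 3-methylphenyl gives a 4.7-fold lower number from compound 2 to compound 4 (0.67 log units; beyond the scatter), so a ring can carry a methyl and still give a low number, provided chlorine is present too. Adding that methyl to the ring of compound 1 gives a 1.4-fold lower number from compound 1 to compound 4 (0.15 log units; within the scatter), and exchanging the 2-chloro-4-fluorophenyl for the 2-chloro-6-methylphenyl gives a 1.3-fold lower number from compound 3 to compound 4 (0.11 log units; within the scatter); neither step can be separated from the scatter, so this place accepts a further methyl on the chlorine-bearing ring as readily as a fluoro, and all three chlorine-bearing rings stand apart from the 3-methylphenyl of compound 2, with no compound shown going against this. Nothing available explains why these rings differ from the 3-methylphenyl ring.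

The compounds shown leave open whether chlorine itself matters or whether another group would serve equally well, such as a bromine, a methoxy or a nitrile on the ring. A plain phenyl ring would show how much any of these groups contributes, and an amine on the ring would test a very different kind of group at this place.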